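Swapping a Difluorophenyl Amide for a Hydroxyphenyl Amide

The source may hold more compounds than are shown below. What is called first, only, known or untested is meant among the compounds shown, and "the series" means these compounds.

Measured so far:
compound 1, `Cn1c(Cc2nn(C)c(=O)c3ccccc23)nnc1SCCCCCCCC(=O)Nc1ccc(F)cc1F`: 2300 nM
compound 2, `Cn1c(Cc2nn(C)c(=O)c3ccccc23)nnc1SCC(=O)Nc1ccc(I)cc1`: "not active" (no number reported)
compound 3, `Cn1c(Cc2nn(C)c(=O)c3ccccc23)nnc1SCC(=O)Nc1ccc(O)cc1`: "not active" (no number reported)

All three compounds share one core and were tested in an assay on isolated protein (Mus musculus) for inhibition of IL15-IL15 receptor (Homo sapiens), read by resazurin assay, with stated times of 30 min and 2.5 days; on this read-out lower numbers stand for stronger inhibition and higher numbers for weaker inhibition. Going by the values given here, compound 1 is the only compound with a number; compound 2 and compound 3, both carrying a much shorter linker to the amide, came back without any number at all.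

Compound 4, `Cn1c(Cc2nn(C)c(=O)c3ccccc23)nnc1SCCCCCCCC(=O)Nc1ccccc1O`, keeps the long linker of compound 1 and changes only the ring on the amide nitrogen: 2-hydroxyphenyl in place of 2,4-difluorophenyl on an amide-type nitrogen.

Among the compounds with values here, no pair of measured compounds differing in a single place is available, so the size of this step cannot be read from the data. Compound 3 also carries a hydroxyphenyl and is not active, but it differs from compound 1 in the linker as well, so it says nothing certain about the ring swap on its own. Taken together, these observations leave the outcome open, and a weakening somewhat beyond the scatter is the more cautious expectation; the step from compound 1 to compound 4 is estimated at a 2.0-fold higher number from compound 1 to compound 4 (0.29 log units; within the scatter). Compound 4 is therefore expected to give 4500 nM in this assay, within a range of 1500 nM to 15000 nM.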

Compound 4, half-maximal inhibitory concentration: 27000 nM
Compound 4: middle estimate off by 6.0-fold (0.78 log units), on the low side, and the stated range ends below it.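

With the long chain held fixed, the ring on the amide nitrogen clearly matters in this assay: 2-hydroxyphenyl in place of 2,4-difluorophenyl gives a 12-fold higher number from compound 1 to compound 4 (1.07 log units; beyond the scatter) and this change lies well outside ordinary assay noise. Going by these compounds alone, this is the first comparison in which only one place changes, whereas compound 2 and compound 3 differ from compound 1 in both the linker and the ring and so could not isolate the ring's contribution. Compound 4 still gives a number, so this swap weakens inhibition without removing it altogether, but no measurement shown here explains the size of the step.

The swap removes two fluorines and adds a hydroxyl in a single move, so the compounds shown cannot tell which of these changes accounts for the loss; a plain phenyl ring or a methoxy group in place of the hydroxyl, on the same long chain, would help to separate the two. Also open, going by these compounds, is how the ring and chain length work together, and whether an amine or a carboxylic acid on the ring would be tolerated.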